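A few compounds are considered here, and "the series" means these few. Any claim that something is new, unique, unknown or untested is made for them only; others in the source may bear on it.

Compound 1 `Cc1ccc(S/C(=C/c2ccc(F)c(C)c2)C(=O)c2ccc(Br)cc2)cc1` is one of two compounds in this series with a number in a functional assay on DU-145 cells (Homo sapiens) for inhibition, read by trypan blue exclusion, with a stated time of 96 h; a higher number here means a weaker inhibitor of growth, a lower number a stronger inhibitor of growth; in this assay compound 1 gives 25000 nM. The other is compound 2 `COc1ccsc1/C=C(\C(=O)c1ccc(Br)cc1)S(=O)(=O)Cc1ccc(Cl)cc1`, which in this assay gives 50000 nM. Compound 1 holds the lower of the two numbers, but the gap to compound 2 lies within the scatter, so the two read as equivalent. Among the compounds with values here, no step between measured compounds is available, and compound 2 differs from compound 1 in more than one place, so the pair supports no reading of any single change.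

Compound 3 `Cc1ccc(S/C(=C/c2ccc(F)cc2F)C(=O)c2ccc(Br)cc2)cc1` has not been measured. It differs from compound 1 in one place: 2,4-difluorophenyl in place of 4-fluoro-3-methylphenyl on a double-bonded chain carbon bound to a double-bonded chain carbon. Within the data shown here, no step in this assay speaks to this exchange, so the expected step from compound 1 to compound 3 is a 1.2-fold higher number from compound 1 to compound 3 (0.08 log units; within the scatter), no larger than the scatter. Compound 3 is therefore estimated at 30000 nM, with a range from 10000 nM to 90000 nM.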

Compound 3, concentration for 50% growth inhibition: > 100000 nM
Compound 3 ended at the assay's limit; the forecaster's own chance of this, stated with the estimate: 20%; middle value at least 3.3-fold (0.52 log units) away from the limit.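

In this assay, the series now has its first single exchange that can be read: on a double-bonded chain carbon bound to a double-bonded chain carbon, 2,4-difluorophenyl in place of 4-fluoro-3-methylphenyl gives an at least 4.0-fold higher number from compound 1 to compound 3 (0.60 log units; beyond the scatter). The two groups match in heavy atom count, in their single six-membered aromatic ring of carbon only and in having no hydrogen-bond donors or acceptors, yet this position does not tolerate the exchange without a step beyond the scatter. Compound 3 gives > 100000 nM, which is a limit of the assay and not a number, so the step has no upper end and rests on this: the limit of > 100000 nM in this assay, at which 1 of the 3 values shown sits.

From the compounds shown here alone, whether the step belongs to the departing methyl or to the entering second fluorine remains open, as one exchange alters both. Also open, going by these compounds, is how this position would respond to a phenyl ring carrying an amine or a carboxylic acid.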